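Methoxymethyl thioether replaces aminoethyl on a pyrazolopyrimidine scaffold

This account rests on a few compounds, and the source may have more. Where it says the series, first, only, none or still open, it means among the compounds named here.

Measured compounds:
compound 1, `CC(C)c1n[nH]c2c(NCc3ccc(-c4ccccn4)cc3)nc(SCC(O)CN3CCNCC3)nc12`, 332 nM
compound 2, `CC(C)c1n[nH]c2c(NCc3ccc(-c4ccccn4)cc3)nc(SCCN)nc12`, 22 nM

In a functional assay on HT cells (Homo sapiens) for antiproliferative activity, read by fluorescence, with a stated time of 72 h (a lower number here means a stronger inhibitor of growth, a higher number a weaker inhibitor of growth), compound 2 gives the lowest of the two numbers; its nearest neighbour is compound 1, which differs from it by a 15-fold lower number from compound 1 to compound 2 (1.18 log units; beyond the scatter). For the measured compounds named here, that single step is the only measured change at this position, and it shows that the group on the saturated chain carbon bound to the sulfur can move the result far beyond the scatter.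

Compound 3, `COCSc1nc(NCc2ccc(-c3ccccn3)cc2)c2[nH]nc(C(C)C)c2n1`, has not yet been measured in this assay. It differs from compound 2 by methoxy in place of aminomethyl on a saturated chain carbon bound to a sulfur. The step from compound 1 to compound 2 concerned the same place but exchanged a much larger group for the aminomethyl; nothing measured tells how the methoxy will fare. Going by the values given here, because the only relevant step, a 15-fold lower number from compound 1 to compound 2 (1.18 log units; beyond the scatter), was large, a sizeable move in either direction is plausible, and the estimate for compound 3 is kept wide. Compound 3 is expected to give 80 nM (range 20 nM to 400 nM), a change of a 3.6-fold higher number from compound 2 to compound 3 (0.56 log units; beyond the scatter) that is expected to run toward weaker inhibition.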

Compound 3, concentration for 50% growth inhibition: 340 nM
The estimate for compound 3 lay 4.3-fold (0.63 log units) below the measured number, within the range that was stated.
By their numbers in this assay, from the lowest: compound 2; then compounds 1 and 3 (each within the scatter of the next).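

In this assay, the step of a 15-fold higher number from compound 2 to compound 3 (1.19 log units; beyond the scatter) shows that the gain seen with compound 2 does not extend to every small group at this place: 2-aminoethyl and methoxymethyl differ here by a nitrogen exchanged for an oxygen and the loss of a hydrogen-bond donor, while the count of 2 heavy atoms in the exchanged groups stays the same. The step of a 1.0-fold higher number from compound 1 to compound 3 (0.01 log units; within the scatter) adds that two very different groups, methoxy and 1-hydroxy-2-(piperazin-1-yl)ethyl, cannot be told apart in this assay, so among these three compounds only compound 2, with its (2-aminoethyl)sulfanyl group, stands apart. Nothing available explains the difference between the aminomethyl and methoxy groups.

As far as these compounds go, it remains open whether the amine itself matters or whether a hydrogen-bond donor alone would suffice, a question that a 2-hydroxyethyl group on the sulfur would address. Also open, from the compounds shown here alone, is how sharply the result depends on the chain, as a 3-aminopropyl group or a 2-(methylamino)ethyl group could show.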